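The source may report more compounds than this note shows. Statements on the series, on what has been measured and on what is new or still open speak of the compounds shown alone.

The measured compounds so far:

Compound 1, `Cc1cnc(Nc2ccc(C#N)cc2)nc1Nc1c(F)cc(-c2cncnc2)cc1F`: in a toxicity assay on MT4 cells (Homo sapiens) for cytotoxicity, read by MTT assay, with a stated time of 5 days (a higher number here means that more compound is tolerated, a lower number that less compound is tolerated), compound 1 gives 900 nM.
Compound 2, `Cc1cnc(Nc2ccc(C#N)cc2)nc1Nc1c(F)cc(-c2cccs2)cc1F`: in this assay compound 2 gives 8000 nM.
Compound 3, `Cc1cc(-c2cccs2)cc(C)c1Nc1ccnc(Nc2ccc(C#N)cc2)n1`: in this assay compound 3 gives 10000 nM.

Compounds 1 and 2 share a core and differ in one place: pyrimidin-5-yl in place of thiophen-2-yl on an aromatic carbon. That change gave an 8.9-fold lower number from compound 2 to compound 1 (0.95 log units; beyond the scatter), so less of compound 1 was tolerated than of compound 2. Compound 3 is built on another core; the difference between the core of compound 2 and the core of compound 3 is not broken down here. In this assay compound 3 and compound 2 lie within the scatter of each other, while compound 3 and compound 1 lie beyond it.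

Compound 4, `Cc1cc(-c2cncnc2)cc(C)c1Nc1ccnc(Nc2ccc(C#N)cc2)n1`, has not been measured. It differs from compound 3 in one place: pyrimidin-5-yl in place of thiophen-2-yl on an aromatic carbon. Among the compounds with values here, this is the same kind of change as the one from compound 2 to compound 1, but not the same: in compound 2 the place is meta to two fluoro groups, in compound 3 it is meta to two methyl groups. Within the data shown here, only one measured example of this change exists, so the expectation rests on it alone. Among the measured compounds shown here, for compound 4 the expected step of a 6.7-fold lower number from compound 3 to compound 4 (0.82 log units; beyond the scatter) is put a little short of an 8.9-fold lower number from compound 2 to compound 1 (0.95 log units; beyond the scatter), the changed surroundings of the place and the single example leaving room for a smaller step. Compound 4 is expected to give 1500 nM in this assay, with a range from 500 nM to 5000 nM.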

Compound 4, half-maximal cytotoxic concentration: 6800 nM
Beside the measured number, compound 4's estimate is 4.5-fold (0.66 log units) below it; the whole stated range lies below it.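

In this assay, putting pyrimidin-5-yl in place of thiophen-2-yl gives a 1.5-fold lower number from compound 3 to compound 4 (0.17 log units; within the scatter), so on this core the swap leaves no change that can be told apart from the normal spread of repeat measurements. The size of the step therefore does not carry over from one core to the other, even though the group leaving, the group entering and the assay are all the same: the same change on two cores in this assay, an 8.9-fold lower number (0.95 log units; beyond the scatter) from compound 2 to compound 1 and a 1.5-fold lower number (0.17 log units; within the scatter) from compound 3 to compound 4, 6.0-fold (0.78 log units) apart, beyond the scatter of two such steps. This shows that the earlier step cannot simply be transferred to a new core in this series, but it does not show which difference between the two cores matters, and two cores give no general rule for a third.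

Still open, as far as these compounds go, is how a compound differing in one place from each of these two cores would behave, which could help narrow down the part of the core that governs the size of the step. Also open, from the compounds shown here alone, is whether other groups at the same place, such as a morpholine, an amine or a carboxylic acid, would give steps that depend on the core in the same way.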